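Triazine ureas: replacing the aryl urea tail

The source may report more compounds than this note shows. Statements on the series, on what has been measured and on what is new or still open speak of the compounds shown alone.

Measured so far in an assay on isolated protein for inhibition of Dihydrofolate reductase (Mus musculus); on this read-out higher numbers stand for higher potency (the scale is a negative logarithm) and lower numbers for lower potency:
- compound 1, `CC1(C)N=C(N)N=C(N)N1c1cccc(CNC(=O)Nc2cccc([N+](=O)[O-])c2)c1`: 8.1
- compound 2, `CC1(C)N=C(N)N=C(N)N1c1ccc(OCCCCCCOc2ccc(S(=O)(=O)F)cc2)c(Cl)c1`: 7.46
- compound 3, `COc1cccc(NC(=O)NCc2cccc(N3C(N)=NC(N)=NC3(C)C)c2)c1`: 8.02

Compound 3 stands second of the three numbers; its neighbour is compound 1, and the two lie within the scatter of each other, while compound 2 lies further off, and that gap is beyond the scatter. Among the measured compounds shown here, the one step that can be read within the set, a number 0.08 log units lower from compound 1 to compound 3 (within the scatter), shows that exchanging the group on the aromatic carbon of the urea tail left this assay unmoved.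

Compound 4, `CCN(CC)C(=O)NCc1cccc(N2C(N)=NC(N)=NC2(C)C)c1`, follows from compound 3 by diethylamino in place of (3-methoxyphenyl)amino on a carbonyl carbon. For the measured compounds named here, no measured step bears on this change directly: the step from compound 1 to compound 3 only swapped a substituent on the aromatic ring, whereas here the whole ring leaves. Going by the values given here, the only other number, that of compound 2, shows that a different, ring-bearing tail gives a lower reading than compound 3, but its structure differs in more than one place, so it sets no step.

With the aromatic ring and its donor gone, a decrease beyond the scatter is expected, estimated as a number 0.72 log units lower from compound 3 to compound 4 (beyond the scatter). For compound 4 the expected value in this assay is 7.3, with a range from 6.6 to 8.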

Compound 4, logarithm of the reciprocal of the active concentration, log(1/C): 6.11
For compound 4 the middle estimate is 1.19 log units above the measured one; the whole stated range lies above it.
By their numbers in this assay, from the lowest: compound 4; then compound 2; then compounds 3 and 1 (each within the scatter of the next).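

In this assay, the carbonyl carbon of the urea tail proves far more sensitive to replacing the whole arylamino group than the aromatic ring was to exchanging its substituent: the earlier exchange gave a number 0.08 log units lower from compound 1 to compound 3 (within the scatter), whereas diethylamino in place of (3-methoxyphenyl)amino gives a number 1.91 log units lower from compound 3 to compound 4 (beyond the scatter), and diethylamino in place of (3-nitrophenyl)amino gives a number 1.99 log units lower from compound 1 to compound 4 (beyond the scatter). The two large steps come from different aryl ureas that read within the scatter of each other, so the drop does not depend on which of these two ring substituents was present. The change removes the six-membered aromatic ring and the hydrogen-bond donor and acceptor of the leaving group together, and no measurement available here explains the drop.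

The compounds shown do not separate the part played by the aromatic ring from that of the amide hydrogen; cyclohexylamino or phenyl(methyl)amino on the same carbonyl carbon would address that question. Also open, as far as these compounds go, is whether a smaller ethylamino group, or a benzylamino group with a longer link to the ring, would keep any of the value seen with the aryl ureas.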